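The source may hold more compounds than are shown below. What is called first, only, known or untested is meant among the compounds shown, and "the series" means these compounds.

Compound 1 `COc1ccc(/C=C(/Sc2ccc(Br)cc2)C(=O)c2ccc(Cl)cc2)cc1` gives the highest number of the two measured in a functional assay on DU-145 cells (Homo sapiens) for inhibition, read by trypan blue exclusion, with a stated time of 96 h; a lower number here means a stronger inhibitor of growth, a higher number a weaker inhibitor of growth: compound 1 shows 50000 nM, while compound 2 `COc1ccc(/C=C(/Sc2ccc(C)cc2)C(=O)c2ccc(Cl)cc2)cc1` shows 1000 nM. Among the measured compounds shown here, the only measured step, a 50-fold lower number from compound 1 to compound 2 (1.70 log units; beyond the scatter), changes a group on the benzene bound to sulfur, not the group altered here. Compound 3 `O=C(/C(=C\c1ccc(F)cc1F)Sc1ccc(Br)cc1)c1ccc(Cl)cc1` differs from compound 1 by 2,4-difluorophenyl in place of 4-methoxyphenyl on a double-bonded chain carbon bound to a double-bonded chain carbon. For the measured compounds named here, no measured step bears on this change, so the direction in this assay is open; the expected step of a 1.7-fold lower number from compound 1 to compound 3 (0.22 log units; within the scatter) is therefore small, within the scatter, with a wide range. Compound 3 is estimated at 30000 nM, between 5000 nM and 100000 nM.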

Compound 3, concentration for 50% growth inhibition: 1000 nM
Compound 3: middle estimate off by 30-fold (1.48 log units), on the high side; the measured number lies below the stated range.
By their numbers in this assay, from the lowest: compounds 2 and 3 (each within the scatter of the next); then compound 1.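

The step of a 50-fold lower number from compound 1 to compound 3 (1.70 log units; beyond the scatter) in this assay shows that the group on a double-bonded chain carbon bound to a double-bonded chain carbon can move the number beyond the scatter, with the bromo group on the benzene bound to sulfur kept. So the series responds at this place as well as on that benzene. No data on hand explain why 2,4-difluorophenyl in place of 4-methoxyphenyl has this effect.

Open, from the compounds shown here alone, is whether both fluorines are needed, and how a dimethylamino group or a carboxylic acid would fare at this place. Also open, going by these compounds, is whether this change and methyl in place of bromo add up when combined.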